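The compounds below may be only part of what the source reports. "The series", "measured", "known", "first", "only" and "open" are said of these compounds alone.

Of the compounds shown here, three built on one shared core have been measured in a functional assay on A549 cells (Homo sapiens) for antiproliferative activity, read by MTT assay, with a stated time of 72 h; on this read-out lower numbers stand for stronger inhibition and higher numbers for weaker inhibition. Compound 1 `COc1cc2c(Oc3ccc(NC(=O)NN4C(=O)CSC4c4c(F)cccc4F)c4ccccc34)ccnc2cc1OCCCN1CCCC1` gives 2360 nM in this assay. Compound 2 `COc1cc2c(Oc3c(F)cc(NC(=O)NN4C(=O)CSC4c4c(F)cccc4F)cc3F)ccnc2cc1OCCCN1CCCC1` gives 560 nM in this assay. Compound 3 `COc1cc2c(Oc3c(F)cc(NC(=O)NN4C(=O)C(C)SC4c4c(F)cccc4F)cc3F)ccnc2cc1OCCCN1CCCC1` gives 830 nM in this assay. On these numbers compound 3 stands second highest of the three. Its nearest neighbour is compound 2, and the step from compound 2 to compound 3 is a 1.5-fold higher number from compound 2 to compound 3 (0.17 log units; within the scatter). Compound 1 lies further away, its number being the highest of the three and beyond the scatter from that of compound 3.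

Compound 4 `COc1cc2c(Oc3c(F)cc(NC(=O)NN4C(=O)C(C)(C)SC4c4c(F)cccc4F)cc3F)ccnc2cc1OCCCN1CCCC1` differs from compound 3 by methyl in place of hydrogen on a saturated ring carbon. Among the compounds with values here, only one measured step bears on this change: the step from compound 2 to compound 3, which likewise put a methyl in place of a hydrogen on a saturated ring carbon of this ring and came out as a 1.5-fold higher number from compound 2 to compound 3 (0.17 log units; within the scatter), within the scatter. A second methyl on the same carbon is therefore expected to give at most a small step, estimated as a 1.2-fold higher number from compound 3 to compound 4 (0.08 log units; within the scatter), probably not beyond the scatter. The estimate for compound 4 in this assay is 1000 nM, with a range from 450 nM to 2300 nM.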

Compound 4, half-maximal inhibitory concentration: 1450 nM
Compound 4: middle estimate off by 1.5-fold (0.16 log units), on the low side; measured number inside the range.
By their numbers in this assay, from the lowest: compounds 2, 3, 4 and 1 (each within the scatter of the next, the first and the last beyond it).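

In this assay, within the data shown here, a second methyl on the saturated ring carbon next to the ring sulfur gives a 1.7-fold higher number from compound 3 to compound 4 (0.24 log units; within the scatter), so this single carbon has now been seen with no methyl, with one and with two, where the earlier compounds showed only the first two of these states. Taken alongside a 1.5-fold higher number from compound 2 to compound 3 (0.17 log units; within the scatter), neither single methyl step can be told apart from the scatter, and the printed values, compound 2 at 560 nM and compound 4 at 1450 nM, show that filling both hydrogen places on this carbon with methyl still leaves a number in the same low-micromolar region of the series rather than abolishing activity. No measurement here accounts for this result, and the data offer no explanation of it.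

The compounds shown leave open how this carbon responds to anything other than methyl, such as an ethyl group, a hydroxymethyl group, an aminomethyl group or a carboxylic acid. They also leave open whether one or two methyl groups on this carbon would give similar steps on the core of compound 1.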